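A few compounds are considered here, and "the series" means these few. Any claim that something is new, unique, unknown or untested is made for them only; others in the source may bear on it.

Measured in an in vitro ADME assay on microsomes (Homo sapiens) for metabolic stability; on this read-out higher numbers stand for fast clearance and lower numbers for slow clearance:
- compound 1 `O=C(CN1CC[C@@H](NC(=O)c2ccc(Cl)s2)C1)Nc1ccc(-n2ccccc2=O)cc1F`: 15.2 mL.min-1.g-1
- compound 2 `O=C(CN1C[C@H](CO)[C@@H](NC(=O)c2ccc(Cl)s2)C1)Nc1ccc(-n2ccccc2=O)cc1F`: 21.7 mL.min-1.g-1
- compound 3 `O=C(CN1C[C@H](NC(=O)c2ccc(Cl)s2)C[C@H]1CO)Nc1ccc(-n2ccccc2=O)cc1F`: 7 mL.min-1.g-1

Compound 3 has the lowest number of the three, at 7 mL.min-1.g-1. Compound 4 `COC[C@@H]1C[C@@H](NC(=O)c2ccc(Cl)s2)CN1CC(=O)Nc1ccc(-n2ccccc2=O)cc1F` differs from it by methyl in place of hydrogen on an oxygen on a saturated carbon, that is, hydroxymethyl to methoxymethyl. Among the compounds with values here, no measured step covers this change directly. The nearest evidence is the two steps that introduce hydroxymethyl: a 2.2-fold lower number from compound 1 to compound 3 (0.34 log units; beyond the scatter), and a 1.4-fold higher number from compound 1 to compound 2 (0.15 log units; within the scatter). Both are small, so only a small move is expected. The expected step, a 1.6-fold higher number from compound 3 to compound 4 (0.20 log units; within the scatter), is a modest rise in this assay, partly back towards compound 1 at 15.2 mL.min-1.g-1. The estimate for compound 4 is 11 mL.min-1.g-1, with an expected range of 5 mL.min-1.g-1 to 24 mL.min-1.g-1.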

Compound 4, intrinsic clearance in microsomes: 34.5 mL.min-1.g-1
The estimate for compound 4 lay 3.1-fold (0.50 log units) below the measured number, and the stated range ends below it.
By their numbers in this assay, from the lowest: compound 3; then compounds 1, 2 and 4 (each within the scatter of the next, the first and the last beyond it).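

In this assay, methyl in place of hydrogen on the oxygen gives a 4.9-fold higher number from compound 3 to compound 4 (0.69 log units; beyond the scatter) and so gives up the low number seen with hydroxymethyl. Set against hydrogen on the saturated ring carbon, methoxymethyl gives a 2.3-fold higher number from compound 1 to compound 4 (0.36 log units; beyond the scatter) while hydroxymethyl gives a 2.2-fold lower number from compound 1 to compound 3 (0.34 log units; beyond the scatter) and thus the opposite direction, so the outcome at this place turns on the group on that oxygen. Nothing available explains this reversal.

Still open, as far as these compounds go, is whether a longer chain on the oxygen, such as ethoxymethyl, reads like methoxymethyl. Also open, from the compounds shown here alone, is how an amine, such as aminomethyl, or a carboxylic acid would read at this place.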